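The source may report more compounds than this note shows. Statements on the series, on what has been measured and on what is new or still open speak of the compounds shown alone.

In a functional assay on OVCAR-3 cells (Homo sapiens) for antiproliferative activity, read by MTT assay, with a stated time of 24 h (a higher number here means a weaker inhibitor, a lower number a stronger inhibitor), compound 1 `O=C(NNc1ccccc1F)c1ccc(NS(=O)(=O)c2cnc(O)nc2O)cc1` gives > 20000 nM, which is a limit of the assay and not a number. Compound 2 `Cc1cccc(NNC(=O)c2ccccc2NS(=O)(=O)c2cnc(O)nc2O)c1` gives > 20000 nM, which is likewise a limit and not a number. Compound 2 therefore has no exact potency, and the two results so far sit together: the limit of > 20000 nM in this assay, at which 2 of the 2 values shown sit.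

Compound 3 `O=C(NNc1ccc(F)cc1)c1ccccc1NS(=O)(=O)c1cnc(O)nc1O` keeps the rest of compound 2 and changes one group: 4-fluorophenyl in place of 3-methylphenyl on an amine nitrogen. Put simply, 4-fluorophenyl comes in place of 3-methylphenyl on an amine nitrogen. For the measured compounds named here, no measured pair shows what this swap does in this assay, so any forecast must lean on very little.

Going by the values given here, the one guide is that compound 1, which also carries a fluorine on a phenyl group, stays at its limit of > 20000 nM. With that in mind, no change beyond the usual scatter is expected, and the estimated step that the limit leaves unreadable from compound 2 to compound 3 has no firm direction. For compound 3 the expected value is 25000 nM, with an estimated range from 12000 nM to 50000 nM, and the assay may well report only a limit again.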

Compound 3, half-maximal inhibitory concentration: > 20000 nM
Compound 3 gave a limit, no number (the forecaster's own chance of this, stated with the estimate: 85%); the middle value lies beyond the limit too.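

In this assay compound 3 gives > 20000 nM, a limit of the assay and not a number. Compound 2 also stands at a limit, so no step can be read between compound 2 and compound 3, and the results sit together: the limit of > 20000 nM in this assay, at which 3 of the 3 values shown sit.

The compounds shown leave open what effect 4-fluorophenyl in place of 3-methylphenyl has on potency.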